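The source may hold more compounds than are shown below. What is called first, only, known or untested is meant among the compounds shown, and "the series" means these compounds.

Working notes on the series. Among the measured compounds shown here, compound 1 `CCCc1nc(-c2ccccc2)c(CNCCN2CCN(c3cccc(C(F)(F)F)c3)CC2)o1` and compound 2 `CCCc1nc(-c2ccccc2)c(CNCCCN2CCN(c3ccccc3Cl)CC2)o1` are the two measured members so far; both carry the shared core, and they differ from each other in more than one place, so no single step is defined between them. In an assay on HEK293 cells for inhibition of Voltage-dependent T-type calcium channel subunit alpha-1G (Homo sapiens), read by fluorescence, tested at 10 uM (a higher number here means more inhibition at the concentration tested (going by the name of the read-out), a lower number less inhibition), compound 1 gives 56.3%. In this assay compound 2 gives 64.7%. For the measured compounds named here, these two numbers lie within the usual scatter of each other, so compound 1 stands level with the only other value recorded, and nothing can be read from this pair about any one structural change.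

Compound 3 `CCCc1nc(-c2ccccc2)c(CNCCN2CCN(c3cccc(Cl)c3)CC2)o1` has not been measured in this assay. It differs from compound 1 in one place: chloro in place of trifluoromethyl on an aromatic carbon. The change stays on the same aromatic carbon and swaps one group for another of the kind already present elsewhere in the series. Going by the values given here, with no measured step that isolates this change, the expectation for compound 3 rests on compound 1 alone, and the expected step of a number 1.3 percentage points lower from compound 1 to compound 3 (within the scatter) is none beyond the scatter in this assay. The value for compound 3 in this assay is accordingly estimated at 55%, within a range from 35% to 75%.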

Compound 3, a percentage reported as inhibition, at one concentration (the size of the read-out at that concentration, not a potency): 51.2%
Beside the measured number, compound 3's estimate is 3.8 percentage points above it; low and high end bracket the measured number.
By their numbers in this assay, from the lowest: compounds 3, 1 and 2 (each within the scatter of the next, the first and the last beyond it).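

Among the compounds shown here, the step of a number 5.1 percentage points lower from compound 1 to compound 3 (within the scatter) in this assay is the first that isolates a single change: chloro in place of trifluoromethyl on an aromatic carbon, with the rest of compound 1 kept. Compound 1 and compound 3 therefore stand level, so at this place on the ring, a group of 1 heavy atom and one of 4 heavy atoms cannot be told apart by this read-out, something the pair of compound 1 and compound 2 could not show. No measurement is available that would account for this result.

Going by these compounds, what remains open is whether any group on this aromatic carbon gives a reading beyond the scatter, for example a methoxy group, a nitrile, an amine or a carboxylic acid, or simply hydrogen in place of the substituent. On these data alone, it is also open whether the swap from 3-(trifluoromethyl)phenyl to 3-chlorophenyl reads the same way when a longer chain joins the two amine nitrogens.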